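Swapping the acyl group on a shikonin-type ester: compound 3

This account rests on a few compounds, and the source may have more. Where it says the series, first, only, none or still open, it means among the compounds named here.

Measured so far:
Compound 1 `CC(=O)OCCC(=O)O[C@H](CC=C(C)C)C1=CC(=O)c2c(O)ccc(O)c2C1=O`: 15700 nM in a functional assay on DU-145 cells (Homo sapiens) for cytotoxicity, read by MTT assay; on this read-out higher numbers stand for weaker inhibition and lower numbers for stronger inhibition
Compound 2 `CC(C)=CC[C@@H](OC(=O)C1CCCCO1)C1=CC(=O)c2c(O)ccc(O)c2C1=O`: 24700 nM in this assay

Compound 1 stands at the lowest of the two numbers; the step of a 1.6-fold higher number from compound 1 to compound 2 (0.20 log units; within the scatter) is small enough to count as no real difference between the two. Compound 3 `CCCCC(C)(O)CC(=O)O[C@H](CC=C(C)C)C1=CC(=O)c2c(O)ccc(O)c2C1=O` is not yet measured. Compared with compound 1 it carries 1-hydroxy-1-methylpentyl in place of acetoxymethyl on a saturated chain carbon bound to a carbonyl carbon. Among the compounds with values here, the only measured step that bears on this, the change of the group on the carbonyl carbon from compound 1 to compound 2, stayed within the scatter, so a change of the same kind gives no ground to expect a shift beyond the scatter in this assay for compound 3. The step from compound 1 to compound 3 is therefore estimated as a 1.0-fold higher number from compound 1 to compound 3 (0.01 log units; within the scatter). The expected value for compound 3 is 16000 nM, with a range from 6000 nM to 45000 nM.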

Compound 3, half-maximal inhibitory concentration: 76500 nM
Compound 3: the middle estimate sits 4.8-fold (0.68 log units) below what was measured; measured number above the stated range.
By their numbers in this assay, from the lowest: compounds 1 and 2 (each within the scatter of the next); then compound 3.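

In this assay, the group on this ester can matter after all: there is a 4.9-fold higher number from compound 1 to compound 3 (0.69 log units; beyond the scatter) and a 3.1-fold higher number from compound 2 to compound 3 (0.49 log units; beyond the scatter), both beyond the scatter, whereas the step between the first two compounds stayed within it. On this read-out a higher number means weaker inhibition, so 2-hydroxy-2-methylhexyl on the carbonyl carbon goes with weaker inhibition than either 2-acetoxyethyl or oxan-2-yl. No measurement offered here explains this shift.

The change from acetoxymethyl to 1-hydroxy-1-methylpentyl alters the carbon chain and the oxygen-bearing groups together, so the compounds shown cannot tell which part goes with the higher number. From the compounds shown here alone, a plain hexyl group would separate the chain from the hydroxy group, and how an amine or a carboxylic acid would read in this place remains open.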